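Phenyl exchange at the edge of the assay limit

A few compounds are considered here, and "the series" means these few. Any claim that something is new, unique, unknown or untested is made for them only; others in the source may bear on it.

In a functional assay on G-361 cells (Homo sapiens) for antiproliferative activity, with a stated time of 72 h (a higher number here means a weaker inhibitor, a lower number a stronger inhibitor), compound 1 `OC[C@H]1O[C@@H](n2cnc3c(NCc4ccc(Br)cc4)ncnc32)[C@H](O)[C@@H]1O` gives > 166000 nM as a limit and not a number. Compound 2 `COc1ccccc1CNc1ncnc2c1ncn2[C@@H]1O[C@H](CO)[C@@H](O)[C@H]1O` gives > 166000 nM which is likewise a limit. For the measured compounds named here, compound 3 `OC[C@H]1O[C@@H](n2cnc3c(NCc4ccc(Cl)cc4Cl)ncnc32)[C@H](O)[C@@H]1O` gives 128000 nM as the only actual number. Beside that number the series has only the limit of > 166000 nM in this assay, at which 2 of the 3 values shown sit, to work from.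

Compound 4 `OC[C@H]1O[C@@H](n2cnc3c(NCc4ccc(F)c(F)c4F)ncnc32)[C@H](O)[C@@H]1O` carries 2,3,4-trifluorophenyl in place of 2,4-dichlorophenyl on a saturated chain carbon bound to a nitrogen on an aromatic ring, and the count of the exchange is 2,3,4-trifluorophenyl in place of 2,4-dichlorophenyl on a saturated chain carbon bound to a nitrogen on an aromatic ring for this one place.

Going by the values given here, two measured steps bear on the same place: an at least 1.2-fold lower number from compound 1 to compound 3 (0.11 log units; that floor lies within the scatter) and an at least 1.2-fold lower number from compound 2 to compound 3 (0.11 log units; that floor lies within the scatter) with both floors lying within the scatter. The third measured step is a step that the two limits leave unreadable from compound 1 to compound 2 and it offers no size to work with. Among compound 1, compound 2 and compound 3 no exchange at this place has shown a step beyond the scatter, so none is expected for the new group in this assay on this evidence.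

The expected change is a 1.1-fold higher number from compound 3 to compound 4 (0.04 log units; within the scatter) and its direction is left open. Compound 4 is estimated at 140000 nM with an expected range from 60000 nM to 300000 nM and a report of only a limit is nearly as likely as a number.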

Compound 4, half-maximal inhibitory concentration: > 166000 nM
Compound 4 gave a limit, no number; the forecaster's own chance of this, stated with the estimate: 45%; middle value at least 1.1-fold (0.07 log units) from the limit.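

In this assay, from the compounds shown here alone, replacing 2,4-dichlorophenyl with 2,3,4-trifluorophenyl gives an at least 1.2-fold higher number from compound 3 to compound 4 (0.11 log units; that floor lies within the scatter), so this exchange adds a step in the opposite direction to those leading to compound 3, though its true size remains unknown. Compound 4 is reported only as a limit, like compound 1 and compound 2, so the steps from those two compounds to compound 4 cannot be read. On a saturated chain carbon bound to a nitrogen on an aromatic ring, four substituted phenyl groups have now been compared without any printed step beyond the scatter, and the read-out offers little room for ranking them: the limit of > 166000 nM in this assay, at which 3 of the 4 values shown sit.

Going by these compounds, whether any group at this place can give a number clearly separated from that of compound 3 remains open, and a pyridine ring, a longer chain carrying the phenyl group or a carboxylic acid on the phenyl ring would each test this. How far compound 1, compound 2 and compound 4 actually lie from compound 3 also remains unresolved, since each has only a limit.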